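The source may hold more compounds than are shown below. What is called first, only, known or untested is meant among the compounds shown, and "the series" means these compounds.

Compound 1 `O=C(NCc1cc(C(F)(F)F)nn1-c1cccc(C(F)(F)F)c1)Nc1cccc2[nH]ncc12` — in an assay on CHO-K1 cells for antagonist activity at transient receptor potential cation channel subfamily V member 1 (Homo sapiens), read by FLIPR and calcium flux, with a stated time of 6 min (on this read-out lower numbers stand for stronger inhibition and higher numbers for weaker inhibition), compound 1 gives 1.3 nM
Compound 2 `Cn1ncc2c(NC(=O)NCc3cc(C(F)(F)F)nn3-c3cccc(F)c3)cccc21` — in the same assay compound 2 gives 7 nM

Among the compounds with values here, of the two numbers measured so far, compound 2 holds the higher one, which on this read-out stands for the weaker inhibition; its nearest neighbour is compound 1, whose number is lower by more than the usual scatter. The two compounds differ in more than one place, so their values show only where each stands, not what any single change does.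

Compound 3 `Cn1ncc2c(NC(=O)NCc3cc(C(F)(F)F)nn3-c3cccc(C(F)(F)F)c3)cccc21` is reached from compound 2 by one change: trifluoromethyl in place of fluoro on an aromatic carbon, a 3-fluorophenyl becoming a 3-(trifluoromethyl)phenyl. Compound 1 also carries a trifluoromethyl on that ring and gives 1.3 nM. Compound 3 is therefore expected to move toward a lower number, with a step of a 2.3-fold lower number from compound 2 to compound 3 (0.37 log units; beyond the scatter), modest but beyond the scatter. The estimate for compound 3 is 3 nM, within a range from 1 nM to 9 nM.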

Compound 3, inhibition constant: 1.4 nM
Estimate against measurement, compound 3: 2.1-fold (0.33 log units) above; low and high end bracket the measured number.
By their numbers in this assay, from the lowest: compounds 1 and 3 (each within the scatter of the next); then compound 2.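

In this assay trifluoromethyl in place of fluoro on an aromatic carbon gives a 5.0-fold lower number from compound 2 to compound 3 (0.70 log units; beyond the scatter) and so shows that the group held at this place on the phenyl ring matters to the read-out. Methyl in place of hydrogen on an aromatic nitrogen gives a 1.1-fold higher number from compound 1 to compound 3 (0.03 log units; within the scatter) and so shows that, with trifluoromethyl on that ring, the two forms of this nitrogen cannot be told apart here. No measurement shown offers an explanation for either step.

The compounds shown leave open whether other groups at the ring position, such as chloro, methoxy or nitrile, would read like fluoro or like trifluoromethyl. They also leave open whether a longer chain on the nitrogen, such as ethyl, would keep the number where it stands, and whether the methyl step would read the same with fluoro on the ring.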